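This account rests on a few compounds, and the source may have more. Where it says the series, first, only, none or still open, it means among the compounds named here.

Compound 1 `COc1cc(C(=O)O)ccc1Cc1cn(C(c2ccccc2)c2ccccc2)c2ccc([N+](=O)[O-])cc12`: 2800 nM
Compound 2 `COc1cc(C(=O)O)ccc1Cc1cn(C(c2ccccc2)c2ccccc2)c2ccc(Cl)cc12`: 1600 nM

Going by the values given here, in an assay for inhibition of leukotriene B4 receptor 1 (Homo sapiens) (on this read-out lower numbers stand for stronger inhibition and higher numbers for weaker inhibition), compound 2 sits at the low end of the two numbers measured so far. Among the compounds with values here, its only neighbour is compound 1, and the step of a 1.8-fold lower number from compound 1 to compound 2 (0.24 log units; within the scatter) lies within the scatter, so no real difference between the two can be claimed. Compound 3 `COc1cc(C(=O)O)ccc1Cc1cn(C(c2ccccc2)c2ccccc2)c2ccc(Br)cc12` differs from compound 2 by bromo in place of chloro on an aromatic carbon. Within the data shown here, the single measured step that bears on this position, a 1.8-fold lower number from compound 1 to compound 2 (0.24 log units; within the scatter), came from a larger swap at the same place and still stayed within the scatter. An exchange of one halogen for another at that place is expected to give no step beyond the scatter in this assay. For compound 3 the estimate in this assay is 1400 nM, with a range from 600 nM to 3200 nM. The expected step is a 1.1-fold lower number from compound 2 to compound 3 (0.06 log units; within the scatter).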

Compound 3, half-maximal inhibitory concentration: 1100 nM
Estimate against measurement, compound 3: 1.3-fold (0.10 log units) above, and the stated range covers the measured number.
By their numbers in this assay, from the lowest: compounds 3, 2 and 1 (each within the scatter of the next, the first and the last beyond it).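

Replacing chloro with bromo on this aromatic carbon gives a 1.5-fold lower number from compound 2 to compound 3 (0.16 log units; within the scatter) in this assay, so the two halogens cannot be told apart here. Going by these compounds alone, the wider comparison adds something new: nitro to bromo at the same carbon gives a 2.5-fold lower number from compound 1 to compound 3 (0.41 log units; beyond the scatter), the only step so far beyond the scatter, though still a modest one, and it shows that a change at this place can shift the number measurably. Nothing shown gives a reason for these differences.

Still open, going by these compounds, is how a fluoro, a nitrile or an amine on this carbon would compare with bromo, and whether any of them would give a larger step. Also open, on these data alone, is whether a methyl group here would stay within the scatter of the halogens.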